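This account rests on a few compounds, and the source may have more. Where it says the series, first, only, none or still open, it means among the compounds named here.

Of the compounds shown here, three sharing one core have been tested in a functional assay on PC-3 cells (Homo sapiens), read by fluorescence and BrdU incorporation, with a stated time of 48 h, tested at 25 uM; on this read-out higher numbers stand for a weaker effect at the one concentration tested and lower numbers for a stronger effect. Compound 1 `COc1cc(OC)c(C(=O)/C=C/c2ccccc2SC)c(OC)c1` gives 0% in this assay. Compound 2 `COc1cccc(/C=C/C(=O)c2c(OC)cc(OC)cc2OC)c1` gives 0.9% in this assay, and compound 3 `COc1cc(OC)c(C(=O)/C=C/c2ccccc2)c(OC)c1` gives 1.7% in this assay. Compound 2 stands among these numbers with no separation that counts: the step of a number 0.9 percentage points higher from compound 1 to compound 2 (within the scatter) and the step of a number 0.8 percentage points higher from compound 2 to compound 3 (within the scatter) both lie within the scatter, as does the step of a number 1.7 percentage points higher from compound 1 to compound 3 (within the scatter).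

Compound 4 `COc1cc(OC)c(C(=O)/C=C/c2ccc(Br)cc2)c(OC)c1` is not yet measured. It differs from compound 2 in one place: 4-bromophenyl in place of 3-methoxyphenyl on a double-bonded chain carbon bound to a double-bonded chain carbon. The step from compound 1 to compound 2 also swaps the whole aryl group on that chain carbon, and the step from compound 2 to compound 3 removes the methoxy from it; neither moved the number beyond the scatter. The swap to 4-bromophenyl is therefore expected to leave the read-out essentially unchanged, with an expected step of a number 1.1 percentage points higher from compound 2 to compound 4 (within the scatter) in this assay. Compound 4 is estimated at 2%, ranging from 0% to 12%.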

Compound 4, a percentage reported as activity, at one concentration (the size of the read-out at that concentration, not a potency): 0.4%
Compound 4: the middle estimate sits 1.6 percentage points above what was measured; low and high end bracket the measured number.
By their numbers in this assay, from the lowest: compounds 1, 4, 2 and 3 (each within the scatter of the next).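

In this assay, for the compounds shown here, bromine is an atom that no earlier compound carries on this aryl group, yet the swap from the 3-methoxyphenyl group gives a number 0.5 percentage points lower from compound 2 to compound 4 (within the scatter) and the swap from the 2-(methylsulfanyl)phenyl group gives a number 0.4 percentage points higher from compound 1 to compound 4 (within the scatter) as well. Placing bromo on the bare phenyl ring gives a number 1.3 percentage points lower from compound 3 to compound 4 (within the scatter) and so also leaves the read-out unseparated. The 3-methoxyphenyl group has a hydrogen-bond acceptor and the 4-bromophenyl group has none, and this difference also produces no step beyond the scatter among these compounds.

No measurement here explains why these changes make so little difference. As far as these compounds go, it remains open whether an amine or a carboxylic acid on this aryl group would move the number beyond the scatter.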